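The source may report more compounds than this note shows. Statements on the series, on what has been measured and on what is new or still open speak of the compounds shown alone.

Compound 1 `CC(C)(O/N=C(\C(=O)N[C@@H]1C(=O)N(S(=O)(=O)O)[C@@H]1CN1CCNC1=O)c1csc(N)n1)C(=O)O` is the starting point of this step. In a physicochemical assay for metabolic stability, read by HPLC and mass spectrometry, in phosphate buffer, at 37 degrees C, at pH 7.4 (on this read-out higher numbers stand for a longer-lived compound and lower numbers for a shorter-lived compound), compound 1 gives > 1000 h, which is a limit of the assay rather than a number, so only a range is known for it (the limit of > 1000 h in this assay, at which 1 of the 2 values shown sits). Going by the values given here, its one measured partner is compound 2 `CC(C)(O/N=C(\C(=O)N[C@@H]1C(=O)N(S(=O)(=O)O)[C@@H]1Cn1ccnn1)c1csc(N)n1)C(=O)O`, which in this assay gives 257 h. The step of an at least 3.8-fold lower number from compound 1 to compound 2 (0.59 log units; beyond the scatter) therefore points toward a shorter-lived compound once the 2-oxoimidazolidin-1-yl group is exchanged for 1H-1,2,3-triazol-1-yl.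

Compound 3 `CC(C)(O/N=C(\C(=O)N[C@@H]1C(=O)N(S(=O)(=O)O)[C@@H]1Cn1cc(CO)nn1)c1csc(N)n1)C(=O)O` has not yet been measured. It carries the change (4-(hydroxymethyl)-1H-1,2,3-triazol-1-yl in place of 2-oxoimidazolidin-1-yl on a saturated chain carbon bound to a saturated ring carbon). Among the compounds with values here, this closely resembles the change from compound 1 to compound 2: both replace the same 2-oxoimidazolidin-1-yl group at the same place, and the group entering compound 3 differs from the one in compound 2 only by the hydroxymethyl within its name. The expectation for compound 3 rests on the step of an at least 3.8-fold lower number from compound 1 to compound 2 (0.59 log units; beyond the scatter), so a drop of comparable size is anticipated. Compound 3 is thus estimated to give 250 h, with a likely range from 100 h to 700 h, an expected step of an at least 4.0-fold lower number from compound 1 to compound 3 (0.60 log units; beyond the scatter).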

Compound 3, half-life: > 37 h
Compound 3: no number, only a limit (the forecaster's own chance of this, stated with the estimate: 10%); the middle value is on the limit's open side.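

In this assay compound 3 gives > 37 h, which is a limit of the assay and not a number. The steps from compound 1 to compound 3 and from compound 2 to compound 3 therefore cannot be read. Going by these compounds alone, what stays open is how long-lived compound 3 really is, and whether hydroxymethyl in place of hydrogen on an aromatic carbon, the one difference between compound 2 and compound 3, shifts the read-out at all.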